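Swapping trifluoromethyl for methoxy on a benzyl amine

The compounds below may be only part of what the source reports. "The series", "measured", "known", "first", "only" and "open" are said of these compounds alone.

Of the compounds shown here, three sharing one core have been tested in a functional assay on MCF7 cells (Homo sapiens) for inhibition, read by MTT assay, with a stated time of 72 h; on this read-out higher numbers stand for weaker inhibition of growth and lower numbers for stronger inhibition of growth. Compound 1 `O=S(=O)(NCCCNCc1cccc(Cl)c1)c1cc(C(F)(F)F)cc(C(F)(F)F)c1` gives 2600 nM, compound 2 `O=S(=O)(NCCCNCc1ccc(C(F)(F)F)cc1)c1cc(C(F)(F)F)cc(C(F)(F)F)c1` gives 1400 nM, and compound 3 `O=S(=O)(NCCCNCC1COc2ccccc2O1)c1cc(C(F)(F)F)cc(C(F)(F)F)c1` gives 2500 nM. Compound 2 has the lowest of the three numbers, but the gaps to its neighbours are small: a 1.8-fold higher number from compound 2 to compound 3 (0.25 log units; within the scatter), and a 1.9-fold lower number from compound 1 to compound 2 (0.27 log units; within the scatter). Neither gap is large enough to call compound 2 stronger than the others.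

Compound 4 `COc1ccc(CNCCCNS(=O)(=O)c2cc(C(F)(F)F)cc(C(F)(F)F)c2)cc1` is the next compound and has not been measured in this assay . It differs from compound 2 in one place: methoxy in place of trifluoromethyl on an aromatic carbon. The measured steps that change the same benzyl group, from compound 1 to compound 2 and from compound 2 to compound 3, both stayed within the scatter, even though they exchanged quite different groups. Nothing in these three compounds shows the benzyl substituent moving the number beyond the scatter, so for compound 4 a step of about a 1.4-fold higher number from compound 2 to compound 4 (0.15 log units; within the scatter) is expected, that is, no real change in either direction. Compound 4 is therefore estimated at 2000 nM, with a likely range from 800 nM to 5000 nM.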

Compound 4, concentration for 50% growth inhibition: 2500 nM
Estimate against measurement, compound 4: 1.3-fold (0.10 log units) below; low and high end bracket the measured number.
By their numbers in this assay, from the lowest: compounds 2, 3, 4 and 1 (each within the scatter of the next).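

The change from trifluoromethyl to methoxy, para to a large group, keeps the aromatic ring and alters only its substituent, and it gives a 1.8-fold higher number from compound 2 to compound 4 (0.25 log units; within the scatter) in this assay. So this swap, which removes three fluorines and adds one hydrogen-bond acceptor, leaves the number within the scatter, a narrower test of this position than the earlier steps, which replaced the whole aryl group. Compound 4 also adds to the flat picture, with no change at the digits printed from compound 3 to compound 4 (within the scatter) and a 1.0-fold lower number from compound 1 to compound 4 (0.02 log units; within the scatter), so all four compounds remain within the scatter of one another, and no other measurement is available to bear on this result.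

The compounds shown leave open whether a carboxylic acid or an amine on the same aromatic carbon, or a longer chain in place of the one in the shared core, would move the number beyond the scatter. They also leave open whether replacing the trifluoromethyl groups of the shared core with methoxy would matter more than the same swap on the benzyl group.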